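This account rests on a few compounds, and the source may have more. Where it says the series, first, only, none or still open, it means among the compounds named here.

Measured compounds:
compound 1 `Cn1c(Cc2nn(C)c(=O)c3ccccc23)nnc1SCCCCCCCC(=O)Nc1ccc(F)cc1F` – 110000 nM
compound 2 `Cn1c(Cc2nn(C)c(=O)c3ccccc23)nnc1SCCCCCCCC(=O)Nc1ccc(Cl)cc1Cl` – 153000 nM
compound 3 `Cn1c(Cc2nn(C)c(=O)c3ccccc23)nnc1SCCCCCCCCCCC(=O)Nc1ccc(Cl)cc1Cl` – 142000 nM

In an assay on cells for inhibition of IL15-IL15 receptor (Homo sapiens), read by AlphaScreen, with stated times of 30 min and 1 h (on this read-out higher numbers stand for weaker inhibition and lower numbers for stronger inhibition), compound 2 gives the highest of the three numbers, yet its gap to compound 3 and to compound 1 is within the scatter, so the three stand level. The unmeasured compound 4 `CC(C)COc1ccc(NC(=O)CCCCCCCSc2nnc(Cc3nn(C)c(=O)c4ccccc34)n2C)cc1` differs from compound 2 only in the group on the amide-type nitrogen: 4-(isobutoxy)phenyl in place of 2,4-dichlorophenyl on an amide-type nitrogen. Going by the values given here, the one measured step that bears on a change at this place is a 1.4-fold higher number from compound 1 to compound 2 (0.14 log units; within the scatter), which stayed within the scatter; compound 3, with a longer chain, sits close to compound 2 as well. On this footing no step beyond the scatter is expected in this assay, and compound 4 is estimated at 140000 nM (range 50000 nM to 400000 nM), meaning an expected step of a 1.1-fold lower number from compound 2 to compound 4 (0.04 log units; within the scatter).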

Compound 4, half-maximal inhibitory concentration: 55000 nM
Estimate against measurement, compound 4: 2.5-fold (0.41 log units) above, within the range that was stated.
By their numbers in this assay, from the lowest: compounds 4, 1, 3 and 2 (each within the scatter of the next, the first and the last beyond it).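

In this assay, the earlier change on the amide-type nitrogen stayed within the scatter, whereas 4-(isobutoxy)phenyl in place of 2,4-dichlorophenyl gives a 2.8-fold lower number from compound 2 to compound 4 (0.44 log units; beyond the scatter), so the number at this position can respond to the group it carries, if only modestly. Against the 2,4-difluorophenyl group, the same entering group gives a 2.0-fold lower number from compound 1 to compound 4 (0.30 log units; within the scatter), which remains within the scatter. Nothing available explains the step.

On these data alone, whether the ether oxygen or the isobutyl part carries the step remains open, as a plain phenyl or methoxyphenyl group would test. Also open, as far as these compounds go, is how 4-(isobutoxy)phenyl behaves on the longer chain of compound 3.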